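The source may report more compounds than this note shows. Statements on the series, on what has been measured and on what is new or still open speak of the compounds shown alone.

Of the compounds shown here, three sharing one core have been measured in a functional assay on BXPC-3 cells (Homo sapiens) for inhibition, read by MTT assay, with a stated time of 7 days; on this read-out higher numbers stand for weaker inhibition and lower numbers for stronger inhibition. Compound 1 `O=C([C@@H]1CCCN(S(=O)(=O)c2ccc(S(=O)(=O)N3CC[C@@H](O)C3)cc2)C1)N1CCC(F)(F)CC1` gives 330 nM. Compound 2 `CCC(CC)S(=O)(=O)c1ccc(S(=O)(=O)N2CCC[C@@H](C(=O)N3CCC(F)(F)CC3)C2)cc1` gives 40 nM. Compound 3 `CCN(CC)C(=O)c1ccc(S(=O)(=O)N2CCC[C@@H](C(=O)N3CCC(F)(F)CC3)C2)cc1` gives 240 nM, which places compound 3 second highest of the three numbers: the step of a 1.4-fold lower number from compound 1 to compound 3 (0.14 log units; within the scatter) lies within the scatter, whereas the step of a 6.0-fold higher number from compound 2 to compound 3 (0.78 log units; beyond the scatter) is a modest rise. Compound 4 `CC(C)CS(=O)(=O)c1ccc(S(=O)(=O)N2CCC[C@@H](C(=O)N3CCC(F)(F)CC3)C2)cc1` has not yet been measured. Its change from compound 3 is isobutylsulfonyl in place of diethylcarbamoyl on an aromatic carbon, so compound 4 carries an alkyl sulfonyl group at the same place where compound 2 carries one. The step that bears most on this is a 6.0-fold higher number from compound 2 to compound 3 (0.78 log units; beyond the scatter) read backwards: exchanging diethylcarbamoyl for (pentan-3-yl)sulfonyl gave the lower number, and isobutylsulfonyl is a closely related chain. The step of an 8.3-fold lower number from compound 1 to compound 2 (0.92 log units; beyond the scatter) points the same way. A modest fall in this assay is therefore expected for compound 4, a 4.0-fold lower number from compound 3 to compound 4 (0.60 log units; beyond the scatter). Compound 4 is estimated at 60 nM, with a range from 25 nM to 150 nM.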

Compound 4, half-maximal inhibitory concentration: 311 nM
For compound 4 the middle estimate is 5.2-fold (0.71 log units) below the measured one; measured number outside the range, above it.
By their numbers in this assay, from the lowest: compound 2; then compounds 3, 4 and 1 (each within the scatter of the next).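

In this assay, a 1.3-fold higher number from compound 3 to compound 4 (0.11 log units; within the scatter) shows that exchanging diethylcarbamoyl for isobutylsulfonyl makes no real difference, so an alkyl sulfonyl group at this aromatic carbon does not by itself give a low number. What is attached to the sulfonyl sulfur matters here: isobutyl in place of pentan-3-yl gives a 7.8-fold higher number from compound 2 to compound 4 (0.89 log units; beyond the scatter) and loses the low number of compound 2, whereas isobutyl in place of 3-hydroxypyrrolidin-1-yl gives only a 1.1-fold lower number from compound 1 to compound 4 (0.03 log units; within the scatter) and no real difference. Among these four compounds, compound 2 alone stands apart, with the lowest number.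

No supporting data explain why these two alkyl chains behave so differently. From the compounds shown here alone, it remains open whether a straight pentyl chain or a cyclopentyl ring on the sulfonyl sulfur would match compound 2 or fall with the others.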